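Replacing the Sulfonyl Group with a Carbamoyl Group

This account rests on a few compounds, and the source may have more. Where it says the series, first, only, none or still open, it means among the compounds named here.

- compound 1 `O=S(=O)(c1ccccc1)N1CCN(c2nccc(Oc3cc(Cl)cc(Cl)c3)n2)CC1`: > 50000 nM (a limit)
- compound 2 `O=S(=O)(c1ccc(F)cc1)N1CCN(c2nccc(Oc3cc(Cl)cc(Cl)c3)n2)CC1`: > 50000 nM (a limit)

These results come from a functional assay on MDA-MB-231 cells (Homo sapiens) for antiproliferative activity, read by MTT assay, with a stated time of 24 h; a higher number here means a weaker inhibitor, a lower number a stronger inhibitor. Compound 2 gives > 50000 nM, which is a limit and not a number. Among the measured compounds shown here, the whole series so far stands at the limit of > 50000 nM in this assay, at which 2 of the 2 values shown sit. For the measured compounds named here, the only measured step is a step that the two limits leave unreadable from compound 1 to compound 2, so it offers no size to carry forward.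

Compound 3 `O=C(Nc1ccccc1Cl)N1CCN(c2nccc(Oc3cc(Cl)cc(Cl)c3)n2)CC1` has (2-chlorophenyl)carbamoyl in place of (4-fluorophenyl)sulfonyl on an amine nitrogen in a ring. Compound 3 is expected to remain weak in this assay because the limit of > 50000 nM in this assay, at which 2 of the 2 values shown sit, is all the data show. The estimated change is small and its direction uncertain: an at least 1.2-fold lower number from compound 2 to compound 3 (0.09 log units; that floor lies within the scatter). For compound 3 the expected value is 40000 nM, with an estimated range of 10000 nM to 100000 nM.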

Compound 3, half-maximal inhibitory concentration: 11000 nM
Estimate against measurement, compound 3: 3.6-fold (0.56 log units) above; the measured number falls inside the stated range.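

In this assay, (2-chlorophenyl)carbamoyl on the amine nitrogen in a ring gives an at least 4.5-fold lower number from compound 2 to compound 3 (0.65 log units; beyond the scatter) when it replaces (4-fluorophenyl)sulfonyl, and an at least 4.5-fold lower number from compound 1 to compound 3 (0.65 log units; beyond the scatter) when it replaces phenylsulfonyl. This position can therefore move the series off its limit, since compound 3 is the first with a readable number: the limit of > 50000 nM in this assay, at which 2 of the 3 values shown sit.

Going by these compounds, the change swaps the linking group and the aromatic ring's substituent together, so which of them carries the step stays open. A phenylcarbamoyl group, without the chlorine, on the same nitrogen would separate the two.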